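Swapping Methoxyphenyl for Difluorophenyl: Expected Cytotoxicity

The source may hold more compounds than are shown below. What is called first, only, known or untested is meant among the compounds shown, and "the series" means these compounds.

Compound 3 `COc1ccc(C(=O)/C=C/c2cc(-c3cc(OC)c(OC)c(OC)c3)n[nH]2)cc1` was tested in a functional assay on SW-620 cells (Homo sapiens) for cytotoxicity, read by sulforhodamine B assay, with a stated time of 48 h, tested at 1 uM (a higher number here means a weaker effect of the compound at the concentration tested, a lower number a stronger effect), where compound 3 gives 82%. This is level with compound 1 `COc1cc(-c2cc(/C=C/C(=O)c3ccc(N)cc3)[nH]n2)cc(OC)c1OC`, which gives 82%; together they are the lowest of the three numbers. Compound 2 `COc1cc(-c2cc(/C=C/C(=O)c3ccc(Cl)c(Cl)c3)[nH]n2)cc(OC)c1OC` gives 91%, and the step of a number 9 percentage points lower from compound 2 to compound 3 (within the scatter) lies within the scatter. Compound 4 `COc1cc(-c2cc(/C=C/C(=O)c3ccc(F)c(F)c3)[nH]n2)cc(OC)c1OC` is not yet measured; it differs from compound 3 in one place: 3,4-difluorophenyl in place of 4-methoxyphenyl on a carbonyl carbon. The step that bears on this is a number 9 percentage points lower from compound 2 to compound 3 (within the scatter), where 3,4-dichlorophenyl rather than a methoxyphenyl stood on the carbonyl carbon, and a number 9 percentage points higher from compound 1 to compound 2 (within the scatter) also stayed within the scatter. Compound 4 is therefore expected to give 88%, between 78% and 98%. The expected step of a number 6 percentage points higher from compound 3 to compound 4 (within the scatter) is small.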

Compound 4, a percentage reported as activity, at one concentration (the size of the read-out at that concentration, not a potency): 93%
Compound 4: middle estimate off by 5 percentage points, on the low side; low and high end bracket the measured number.
By their numbers in this assay, from the lowest: compounds 1, 3, 2 and 4 (each within the scatter of the next, the first and the last beyond it).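

Within the data shown here, at the carbonyl carbon, 3,4-difluorophenyl gives the first steps beyond the scatter in this assay, both toward a weaker effect: a number 11 percentage points higher from compound 3 to compound 4 (beyond the scatter) and a number 11 percentage points higher from compound 1 to compound 4 (beyond the scatter). The change from 3,4-dichlorophenyl stays within the scatter, with a number 2 percentage points higher from compound 2 to compound 4 (within the scatter), so these two groups cannot be told apart here. Nothing available explains the difference between these groups. Still open, on these data alone, is how a carboxylic acid or a longer chain would read at this carbonyl carbon, and whether any group there gives a clearly stronger effect than compound 1 and compound 3.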